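The compounds below may be only part of what the source reports. "The series", "measured", "known", "first", "only" and "open" are said of these compounds alone.

Measured compounds:
compound 1 `COc1ccc(Sc2nc3cc(N)cc(N)c3nc2-c2ccccc2)cc1` — in a functional assay on COLO 205 cells (Homo sapiens) for inhibition, read by sulforhodamine B assay, with a stated time of 48 h (a higher number here means a weaker inhibitor of growth, a lower number a stronger inhibitor of growth), compound 1 gives < 100000 nM, which is a limit of the assay.
compound 2 `Nc1cc(N)c2nc(-c3ccccc3)c(Sc3ccc(Cl)c(Cl)c3)nc2c1` — in this assay compound 2 gives 33900 nM.

Among the compounds with values here, compound 2 thus holds the only number in this assay; the further value is a limit. The step that the limit leaves unreadable from compound 1 to compound 2 cannot be read because of the limit of < 100000 nM in this assay, at which 1 of the 2 values shown sits. Compound 3 `Nc1cc(N)c2nc(-c3ccccc3)c(Sc3ccc(F)cc3)nc2c1` differs from compound 2 by 4-fluorophenyl in place of 3,4-dichlorophenyl on a sulfur. Within the data shown here, no measured step bears readably on this change, so neither size nor direction can be taken from the series. Compound 3 is expected near 50000 nM, with a range of 20000 nM to 120000 nM. The estimated step of a 1.5-fold higher number from compound 2 to compound 3 (0.17 log units; within the scatter) stays within the usual scatter.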

Compound 3, concentration for total growth inhibition: 47900 nM
Estimate against measurement, compound 3: 1.0-fold (0.02 log units) above, and the stated range covers the measured number.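

Within the data shown here, the first readable step at this sulfur is a 1.4-fold higher number from compound 2 to compound 3 (0.15 log units; within the scatter), so 3,4-dichlorophenyl and 4-fluorophenyl are not told apart in this assay. Two quite different halogenated phenyl groups on the sulfur thus give values within the scatter of each other. The steps from compound 1 to the other two compounds cannot be read because compound 1 carries a limit and not a number: the limit of < 100000 nM in this assay, at which 1 of the 3 values shown sits.

Still open, as far as these compounds go, is whether a carboxylic acid or an amine on the phenyl ring carried by the sulfur, or a longer chain in place of that ring, would give a step beyond the scatter.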